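Swapping the Pyrrolidine for an Imidazole on Compound 3

The source may hold more compounds than are shown below. What is called first, only, known or untested is meant among the compounds shown, and "the series" means these compounds.

Of the compounds shown here, three sharing one core have been measured in a functional assay on U-87MG ATCC cells (Homo sapiens) for cytotoxicity, read by MTT assay, with a stated time of 72 h; on this read-out higher numbers stand for weaker inhibition and lower numbers for stronger inhibition. Compound 1 `COc1ncc(-c2ccc3nccc(N4CCCC4)c3c2)cc1NS(=O)(=O)c1ccc(F)cc1F` gives 6690 nM, compound 2 `COc1ncc(-c2ccc3nccc(-c4ccc(C)cc4)c3c2)cc1NS(=O)(=O)c1ccc(F)cc1F` gives 67100 nM, and compound 3 `COc1ncc(-c2ccc3nccc(-c4ccc(CN5CCCC5)cc4)c3c2)cc1NS(=O)(=O)c1ccc(F)cc1F` gives 159 nM, the lowest of the three numbers in this assay. The step of a 10-fold higher number from compound 1 to compound 2 (1.00 log units; beyond the scatter) is modest, whereas a 42-fold lower number from compound 1 to compound 3 (1.62 log units; beyond the scatter) and a 420-fold lower number from compound 2 to compound 3 (2.63 log units; beyond the scatter) are both large, so the substituent on the saturated chain carbon bound to an aromatic carbon has so far decided the number.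

Compound 4 `COc1ncc(-c2ccc3nccc(-c4ccc(Cn5ccnc5)cc4)c3c2)cc1NS(=O)(=O)c1ccc(F)cc1F` changes exactly that substituent: 1H-imidazol-1-yl in place of pyrrolidin-1-yl on a saturated chain carbon bound to an aromatic carbon. Going by the values given here, no measured step compares these two groups directly; the only step touching this carbon, a 420-fold lower number from compound 2 to compound 3 (2.63 log units; beyond the scatter), shows how much the number moved when the pyrrolidin-1-yl was put in place of hydrogen. Since a different ring now occupies that spot, some of that gain is expected to be lost, but not all of it, and the estimated step is a 5.0-fold higher number from compound 3 to compound 4 (0.70 log units; beyond the scatter). Compound 4 is accordingly expected to give about 800 nM in this assay, with a range from 200 nM to 4000 nM.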

Compound 4, half-maximal inhibitory concentration: 600 nM
The estimate for compound 4 lay 1.3-fold (0.12 log units) above the measured number; measured number inside the range.
By their numbers in this assay, from the lowest: compound 3; then compound 4; then compound 1; then compound 2.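

In this assay, the saturated chain carbon bound to an aromatic carbon turns out not to depend on pyrrolidin-1-yl alone: 1H-imidazol-1-yl in its place gives a 3.8-fold higher number from compound 3 to compound 4 (0.58 log units; beyond the scatter), a modest loss, while the same ring in place of hydrogen still gives a 110-fold lower number from compound 2 to compound 4 (2.05 log units; beyond the scatter), a large gain. On the aromatic carbon, 4-((1H-imidazol-1-yl)methyl)phenyl in place of pyrrolidin-1-yl gives an 11-fold lower number from compound 1 to compound 4 (1.05 log units; beyond the scatter), so a second ring at the chain carbon also retains a large gain in this comparison. Nothing measured here explains the gap between the two five-membered rings.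

As far as these compounds go, what a morpholin-4-yl or an open-chain dimethylamino group would give on this carbon stays open, as does the effect of a longer chain carrying the pyrrolidin-1-yl. From the compounds shown here alone, whether compound 3 and compound 4 keep this order in other cells also stays open.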